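A few compounds are considered here, and "the series" means these few. Any claim that something is new, unique, unknown or untested is made for them only; others in the source may bear on it.

Three compounds on one shared core differ only in the group on an amide-type nitrogen. In a functional assay on NCI-H460 cells (Homo sapiens) for inhibition, read by CCK-8 assay, with a stated time of 72 h, tested at 1 uM (on this read-out higher numbers stand for more inhibition of growth at the one concentration tested and lower numbers for less inhibition of growth), compound 1 (`CN(C)C(=O)c1cc2cnc(Nc3ccc(NC(=O)C4(C(=O)Nc5cccc(O)c5)CC4)cc3)nc2n1C1CCCC1`) gives 75.5% with a 3-hydroxyphenyl group there. Compound 2 (`CN(C)C(=O)c1cc2cnc(Nc3ccc(NC(=O)C4(C(=O)Nc5ccccc5F)CC4)cc3)nc2n1C1CCCC1`) gives 28.2% with a 2-fluorophenyl group. Compound 3 (`CN(C)C(=O)c1cc2cnc(Nc3ccc(NC(=O)C4(C(=O)Nc5cccc(Cl)c5)CC4)cc3)nc2n1C1CCCC1`) gives 44% with a 3-chlorophenyl group, which makes it second highest of the three, above compound 2 and below compound 1.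

Compound 4 (`CN(C)C(=O)c1cc2cnc(Nc3ccc(NC(=O)C4(C(=O)Nc5ccc(Br)cc5)CC4)cc3)nc2n1C1CCCC1`) has not yet been measured. It carries 4-bromophenyl in place of 3-chlorophenyl on an amide-type nitrogen. Among the measured compounds shown here, no measured step makes this exact exchange, so the evidence is indirect. The closest case is the swap of one halogen-bearing phenyl for another, which gave a number 15.8 percentage points higher from compound 2 to compound 3 (beyond the scatter) and is only a modest step. The two large steps, a number 47.3 percentage points lower from compound 1 to compound 2 (beyond the scatter) and a number 31.5 percentage points lower from compound 1 to compound 3 (beyond the scatter) both take away the hydroxy group, and no hydroxy group is involved in the change at hand. A step of modest size at most is therefore expected in this assay and its direction is open. The expected step is a number 4 percentage points lower from compound 3 to compound 4 (within the scatter) and this estimate leaves a real change possible either way. Compound 4 is estimated at 40% (range 20% to 62%).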

Compound 4, percent growth inhibition at one concentration: 31.5%
Estimate against measurement, compound 4: 8.5 percentage points above; low and high end bracket the measured number.
By their numbers in this assay, from the lowest: compounds 2 and 4 (each within the scatter of the next); then compound 3; then compound 1.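

In this assay, the exchange of 3-chlorophenyl for 4-bromophenyl on the amide-type nitrogen gives a number 12.5 percentage points lower from compound 3 to compound 4 (beyond the scatter), so two phenyl groups that each carry one halogen, and have the same heavy-atom count, are not interchangeable at this position. The 2-fluorophenyl and 4-bromophenyl groups, by contrast, cannot be told apart here, with a number 3.3 percentage points higher from compound 2 to compound 4 (within the scatter), while a number 44 percentage points lower from compound 1 to compound 4 (beyond the scatter) means that all three halogen-bearing compounds now stand well below the 3-hydroxyphenyl compound, with no exception among those shown. Nothing measured here explains these differences.

The exchange from compound 3 to compound 4 alters both the halogen and its place on the ring, so a bromophenyl and a chlorophenyl group with the halogen at the same ring position would be needed to show which of the two changes matters. Going by these compounds, it also remains open whether the high value of compound 1 is particular to the hydroxy group, or whether an amine or a carboxylic acid in its place on the phenyl ring would give a similar result.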